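A few compounds are considered here, and "the series" means these few. Any claim that something is new, unique, unknown or untested is made for them only; others in the source may bear on it.

Compound 1 `COC(=O)CC(=O)N1N=C(c2ccc(N3CCN(C)CC3)cc2)CC1c1ccc(N(C)C)cc1` and compound 2 `Cc1ccc(C(=O)N2N=C(c3ccc(N4CCN(C)CC4)cc3)CC2c2ccc(N(C)C)cc2)cc1` share a core and differ only at the group carried by the amine nitrogen in the ring. In a functional assay on MDA-MB-231 cells (Homo sapiens) for inhibition, read by sulforhodamine B assay, tested at 10 uM (a lower number here means less inhibition, a higher number more inhibition at the concentration tested (going by the name of the read-out)), compound 1 gives -0.4%; in this assay compound 2 gives -0.7%. Compound 1 stands highest of the two numbers, with compound 2 nearest, and the step of a number 0.3 percentage points lower from compound 1 to compound 2 (within the scatter) lies within the scatter: both values sit at no measurable inhibition.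

Compound 3 `CN1CCN(c2ccc(C3=NN(S(=O)(=O)c4ccc(C#N)cc4)C(c4ccc(N(C)C)cc4)C3)cc2)CC1` is unmeasured. Relative to compound 1 it carries (4-cyanophenyl)sulfonyl in place of ((methoxycarbonyl)methyl)carbonyl on an amine nitrogen in a ring. Among the compounds with values here, the one measured step, from compound 1 to compound 2, also exchanges the group on that ring nitrogen and produced nothing beyond the scatter, so a step of similar size is expected for compound 3, a number 2.4 percentage points higher from compound 1 to compound 3 (within the scatter), with no direction beyond the scatter. Within the data shown here, the sulfonyl-bearing group has no measured precedent here, so the range is kept wide.

For compound 3 in this assay the estimate is 2%, between -12% and 25%.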

Compound 3, a percentage reported as inhibition, at one concentration (the size of the read-out at that concentration, not a potency): 99.8%
Compound 3: middle estimate off by 97.8 percentage points, on the low side, outside the stated range (above it).
By their numbers in this assay, from the lowest: compounds 2 and 1 (each within the scatter of the next); then compound 3.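

The group on the amine nitrogen in a ring is not a silent position in this assay: (4-cyanophenyl)sulfonyl gives a number 100.2 percentage points higher from compound 1 to compound 3 (beyond the scatter) and a number 100.5 percentage points higher from compound 2 to compound 3 (beyond the scatter) in the same exchange against (4-methylphenyl)carbonyl. Compounds 1 and 2, both carbonyl-linked, had shown no response to this position, so the change to a sulfonyl-linked group is the first to separate compounds in the series, though it replaces the link and the whole group at once. No measurement at hand gives a reason for the step.

Open, on these data alone, is whether the sulfonyl link or the nitrile on the ring accounts for the step: (4-methylphenyl)sulfonyl and (4-cyanophenyl)carbonyl on the same nitrogen would tell these apart. Also open, as far as these compounds go, is whether a sulfonyl group with no aromatic ring, such as methylsulfonyl, keeps the effect.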